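Imine aryl variation in the urea-linked series

The source may hold more compounds than are shown below. What is called first, only, known or untested is meant among the compounds shown, and "the series" means these compounds.

Going by the values given here, compound 3 `CN(C)CCn1cnnc1-c1cc(Oc2ccc(NC(=O)N/N=C/c3ccc(F)cc3F)cc2F)ccn1` gives the lowest number of the three measured so far in a functional assay on MKN-45 cells (Homo sapiens) for cytotoxicity, read by MTT assay, with a stated time of 72 h (a higher number here means a weaker inhibitor, a lower number a stronger inhibitor), at 810 nM, though all three lie within the scatter of one another. Compound 2 `CN(C)CCn1cnnc1-c1cc(Oc2ccc(NC(=O)N/N=C/c3ccc(F)cc3)cc2F)ccn1` gives 1030 nM and compound 1 `COc1ccc(OC)c(/C=N/NC(=O)Nc2ccc(Oc3ccnc(-c4nncn4CCN(C)C)c3)c(F)c2)c1` gives 1510 nM. The three steps that vary the aryl on the carbon with a double bond to nitrogen, a 1.5-fold lower number from compound 1 to compound 2 (0.17 log units; within the scatter), a 1.9-fold lower number from compound 1 to compound 3 (0.27 log units; within the scatter) and a 1.3-fold lower number from compound 2 to compound 3 (0.10 log units; within the scatter), all stay within the scatter, so this position has so far tolerated a 2,5-dimethoxyphenyl, a 4-fluorophenyl and a 2,4-difluorophenyl without a clear shift.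

Compound 4 `CN(C)CCn1cnnc1-c1cc(Oc2ccc(NC(=O)N/N=C/c3ccc(O)c(O)c3)cc2F)ccn1` carries 3,4-dihydroxyphenyl in place of 2,4-difluorophenyl on a carbon with a double bond to nitrogen. Among the compounds with values here, none of the measured aryls carried a hydrogen-bond donor, so the nearest comparison is compound 1 with its 2,5-dimethoxyphenyl at 1510 nM, and no measured step covers the entering group itself. Given the flat picture so far, the step of a 1.5-fold higher number from compound 3 to compound 4 (0.17 log units; within the scatter) is expected to stay within the scatter. Compound 4 is therefore estimated at 1200 nM in this assay, with a range from 500 nM to 3000 nM.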

Compound 4, half-maximal inhibitory concentration: 3240 nM
Estimate against measurement, compound 4: 2.7-fold (0.43 log units) below; the measured number lies above the stated range.
By their numbers in this assay, from the lowest: compounds 3, 2 and 1 (each within the scatter of the next); then compound 4.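

Against the three aryls without hydrogen-bond donors, 3,4-dihydroxyphenyl on the carbon with a double bond to nitrogen gives the first shifts beyond the scatter in this assay, all towards a weaker inhibitor (a 4.0-fold higher number from compound 3 to compound 4 (0.60 log units; beyond the scatter); a 3.1-fold higher number from compound 2 to compound 4 (0.50 log units; beyond the scatter); a 2.1-fold higher number from compound 1 to compound 4 (0.33 log units; beyond the scatter)). This position therefore does not accept every aryl equally: the fluorinated and methoxy-bearing aryls stay within the scatter of one another, while the dihydroxy aryl of compound 4 stands apart from all three. The shift and the presence of hydrogen-bond donors coincide in this single compound, and nothing measured here accounts for the shift.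

With only one aryl carrying hydroxyl groups, the compounds shown do not separate the effect of those groups from that of their placement on the ring. As far as these compounds go, whether an aminophenyl or a carboxyphenyl at this place would also give a higher number remains open.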